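An Amide Swap at the Assay Limit

The compounds below may be only part of what the source reports. "The series", "measured", "known", "first", "only" and "open" are said of these compounds alone.

Three relatives sharing one core were tested in a functional assay on Caco-2 cells (Homo sapiens) for antiproliferative activity, read by MTT assay, with a stated time of 48 h (a lower number here means a stronger inhibitor, a higher number a weaker inhibitor), as the starting evidence. Compound 1 (`C#CC(C)OC(=O)c1ccc(C(CC)(CC)c2ccc(OCCC(O)(CC)CC)c(C)c2)n1CC`) reads > 50000 nM as a limit and not a number. Compound 2 (`CCn1c(C(=O)Nc2cccc(C(F)(F)F)c2)ccc1C(CC)(CC)c1ccc(OCCC(O)(CC)CC)c(C)c1`) reads > 50000 nM as a limit too. Compound 3 (`CCOc1ccc(NC(=O)c2ccc(C(CC)(CC)c3ccc(OCCC(O)(CC)CC)c(C)c3)n2CC)cc1`) reads > 50000 nM as a limit as well. All three therefore stand at the same place (the limit of > 50000 nM in this assay, at which 3 of the 3 values shown sit).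

Compound 4 (`CCC(C)C(NC(=O)c1ccc(C(CC)(CC)c2ccc(OCCC(O)(CC)CC)c(C)c2)n1CC)C(=O)OC`) alters compound 3 on an amide-type nitrogen (a group of 9 heavy atoms (7 carbon, 2 oxygen; no ring) in place of a group of 9 heavy atoms (8 carbon, 1 oxygen; one six-membered aromatic ring of carbon only), on an amide-type nitrogen). The closest evidence is a change on that same nitrogen (a step that the two limits leave unreadable from compound 2 to compound 3). Two changes on a carbonyl carbon (a step that the two limits leave unreadable from compound 1 to compound 2 and a step that the two limits leave unreadable from compound 1 to compound 3) also bear on it. None of these steps has a readable size or direction. No step beyond the scatter is therefore expected in this assay, and no direction can be argued. The expected step (a number no higher from compound 3 to compound 4 (the limit leaves the size open)) is correspondingly small. The estimate for compound 4 is 50000 nM with an expected range from 20000 nM to 100000 nM and a report as a limit is likely.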

Compound 4, half-maximal inhibitory concentration: > 50000 nM
Compound 4 ended at the assay's limit; the forecaster's own chance of this, stated with the estimate: 70%; the middle value sits exactly at the limit.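

Compound 4 joins compound 1, compound 2 and compound 3 as a limit and not a number in this assay, so no step among these four compounds can be read: the limit of > 50000 nM in this assay, at which 4 of the 4 values shown sit.

The compounds shown leave open whether any change on the amide-type nitrogen or the carbonyl carbon alters the antiproliferative activity at all.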